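Replacing dimethylamino with 4-methylpiperazin-1-yl

The source may report more compounds than this note shows. Statements on the series, on what has been measured and on what is new or still open speak of the compounds shown alone.

Of the compounds shown here, three sharing related structures have been measured so far. In a functional assay on HL-60 cells (Homo sapiens) for antiproliferative activity, read by MTT assay, with a stated time of 48 h (a higher number here means a weaker inhibitor, a lower number a stronger inhibitor), compound 1 `CC(=O)OC/C1=C/C[C@](C)(CCC=C(C)C)/C=C/[C@@H](OC(=O)C=C(C)C)[C@](C)(O)/C=C/C1=O` gives 2950 nM while compound 2 `C=C1/C=C/C(=O)/C(CO)=C\C[C@](C)(CCC=C(C)C)/C=C/[C@H]1OC(=O)C=C(C)C` gives 2810 nM and compound 3 `CC(C)=CCC[C@](C)(/C=C/[C@@H](OC(=O)C=C(C)C)[C@](C)(O)/C=C/C(=O)/C=C/N(C)C)CC=O` gives 4690 nM as its half-maximal inhibitory concentration. Compound 3 therefore stands within the usual scatter of both other compounds, and these numbers cannot be ranked against one another.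

Compound 4 `CC(C)=CCC[C@](C)(/C=C/[C@@H](OC(=O)C=C(C)C)[C@](C)(O)/C=C/C(=O)/C=C/N1CCN(C)CC1)CC=O` has not yet been measured. It differs from compound 3 in one place, where 4-methylpiperazin-1-yl stands in place of dimethylamino on a double-bonded chain carbon bound to a double-bonded chain carbon. The counted difference is 4-methylpiperazin-1-yl in place of dimethylamino on a double-bonded chain carbon bound to a double-bonded chain carbon and the rest of the structure stays as it is in compound 3.

Among the measured compounds shown here, no two measured compounds differ in only one place, so the data offer no direct guide to the size of this change. The expectation rests on compound 3 at 4690 nM and assumes no step beyond the scatter in this assay in either direction. The estimated step of a 1.2-fold lower number from compound 3 to compound 4 (0.07 log units; within the scatter) is expected to remain within that scatter. For compound 4 the expected value is 4000 nM with an estimated span from 1800 nM to 9000 nM as the likely range.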

Compound 4, half-maximal inhibitory concentration: 1060 nM
Beside the measured number, compound 4's estimate is 3.8-fold (0.58 log units) above it; measured number outside the range, below it.
By their numbers in this assay, from the lowest: compound 4; then compounds 2, 1 and 3 (each within the scatter of the next).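

In this assay, placing 4-methylpiperazin-1-yl in place of dimethylamino on a double-bonded chain carbon bound to a double-bonded chain carbon gives a 4.4-fold lower number from compound 3 to compound 4 (0.65 log units; beyond the scatter). This is the only step shown that can be read and it lies beyond the scatter, so the amine at this place does bear on the antiproliferative read-out, something the earlier compounds could not show because none of them differed in only one place. The change replaces an open-chain dimethylamino group with one six-membered non-aromatic ring with 2 hetero atoms, but nothing measured here explains why the number falls.

The compounds shown leave open which part of the entering group carries the step: the ring, its second nitrogen or the methyl on that nitrogen. Piperidin-1-yl, morpholin-4-yl and an unsubstituted piperazin-1-yl at the same place would separate these parts, while a single pair cannot say whether the same swap would give a similar step on a different core.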